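A few compounds are considered here, and "the series" means these few. Any claim that something is new, unique, unknown or untested is made for them only; others in the source may bear on it.

Measured compounds:
Compound 1 `Cc1n[nH]c2ccc(-c3nc4cnc(N5CCN(C)CC5)cn4c3Nc3ccc(Br)cc3)cc12`: in a functional assay on MV4-11 cells (Homo sapiens) for inhibition, with a stated time of 120 h, tested at 10 uM (on this read-out lower numbers stand for less inhibition and higher numbers for more inhibition at the one concentration tested (going by the name of the read-out)), compound 1 gives 83%.
Compound 2 `Cc1n[nH]c2ccc(-c3nc4cnc(N5CCN(C)CC5)cn4c3Nc3ccc(I)cc3)cc12`: in this assay compound 2 gives 0%.
Compound 3 `Cc1ccc(C)c(Nc2c(-c3ccc4[nH]nc(C)c4c3)nc3cnc(N4CCN(C)CC4)cn23)c1`: in this assay compound 3 gives 0%.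

Compound 3 stands level with compound 2, and the two together are the lowest of the three numbers; compound 1 lies far above them, as the step of a number 83 percentage points lower from compound 1 to compound 3 (beyond the scatter) shows.

The unmeasured compound 4 `Cc1n[nH]c2ccc(-c3nc4cnc(N5CCN(C)CC5)cn4c3Nc3ccc(Br)cc3Cl)cc12` differs from compound 3 in one place: 4-bromo-2-chlorophenyl in place of 2,5-dimethylphenyl on a nitrogen on an aromatic ring. Within the data shown here, two measured steps bear on this change. Replacing 4-bromophenyl by 2,5-dimethylphenyl gave a number 83 percentage points lower from compound 1 to compound 3 (beyond the scatter), while replacing 4-iodophenyl by 2,5-dimethylphenyl gave no change at the digits printed from compound 2 to compound 3 (within the scatter). Compound 4 again carries a bromo on the ring, as compound 1 does, so a return toward the high value of compound 1 is possible. Yet the step of a number 83 percentage points lower from compound 1 to compound 2 (beyond the scatter) shows that exchanging one halogen for another can remove all inhibition, and the added chloro in compound 4 has no measured counterpart at all. The step expected for compound 4 is therefore a rise, estimated as a number 45 percentage points higher from compound 3 to compound 4 (beyond the scatter), and this expectation is a very uncertain one. The estimate for compound 4 is 45%, with a range from 5% to 85%.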

Compound 4, a percentage reported as inhibition, at one concentration (the size of the read-out at that concentration, not a potency): 70.5%
Compound 4: middle estimate off by 25.5 percentage points, on the low side, and the stated range covers the measured number.
By their numbers in this assay, from the lowest: compounds 2 and 3 (each within the scatter of the next); then compound 4; then compound 1.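

The swap of 2,5-dimethylphenyl for 4-bromo-2-chlorophenyl on the nitrogen gives a large rise in this assay, a number 70.5 percentage points higher from compound 3 to compound 4 (beyond the scatter), and the comparison with 4-iodophenyl gives a rise of the same size, a number 70.5 percentage points higher from compound 2 to compound 4 (beyond the scatter), so high inhibition at this position is no longer confined to compound 1. Adding a chloro in place of hydrogen on the aromatic ring of compound 1 brings only a modest drop, a number 12.5 percentage points lower from compound 1 to compound 4 (beyond the scatter), which shows that this ring can carry a further group and keep most of its inhibition, in clear contrast to the complete loss seen on exchanging bromo for iodo. Both bromo-bearing compounds therefore sit high and compounds 2 and 3 sit at the bottom, but nothing available here gives a reason for this split.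

As far as these compounds go, whether the bromo itself is what counts remains open, since a 4-chlorophenyl or a 4-methoxyphenyl group on the same nitrogen could separate its role from that of any other group there. The single concentration also leaves open how compound 1 and compound 4 would compare in potency.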